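The source may report more compounds than this note shows. Statements on the series, on what has been measured and on what is new or still open speak of the compounds shown alone.

Measured in an ADME assay on HII4E cells (Mus musculus) for cytotoxicity, read by MTT assay, with a stated time of 48 h; on this read-out higher numbers stand for weaker inhibition and lower numbers for stronger inhibition:
- compound 1 `CC(=O)OC[C@H]1O[C@H](OCC(=O)NCc2cn(Cc3ccccc3)nn2)[C@H](O)[C@@H](OC(C)=O)[C@H]1OC(C)=O` gives 879 ug/mL
- compound 2 `O=C(CO[C@H]1O[C@H](CO)[C@H](O)[C@H](O)[C@H]1O)NCc1cn(Cc2ccccc2)nn1` gives 617 ug/mL
- compound 3 `O=C(CO[C@H]1O[C@H](CO)[C@@H](O)[C@H](O)[C@H]1O)NCc1cn(Cc2ccccc2)nn1` gives 193 ug/mL

Compound 3 has the lowest of these three numbers, clearly below both others. Compound 4 `O=C(CO[C@@H]1O[C@H](CO)[C@@H](O)[C@H](O)[C@H]1O)NCc1cn(Cc2ccccc2)nn1` is related to it by the two compounds have the same atoms and bonds and differ only in configuration as drawn: 1 of 5 stereo elements differ; a stereocentre at a saturated ring carbon is drawn S in compound 3 and R in compound 4, so only the spatial arrangement at one ring carbon changes. One measured step is of this kind, a 3.2-fold lower number from compound 2 to compound 3 (0.50 log units; beyond the scatter), and it is attributed to configuration due to the fact that compounds 2 and 3 differ only in the configuration as drawn. A change of similar size is therefore expected in this assay. The direction is uncertain, but a higher number seems likelier, given that compound 3 at 193 ug/mL is the lowest so far. The expected change is a 1.6-fold higher number from compound 3 to compound 4 (0.19 log units; within the scatter). For compound 4 the estimated value is 300 ug/mL. The estimated range for compound 4 runs from 110 ug/mL to 800 ug/mL.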

Compound 4, half-maximal inhibitory concentration: 426 ug/mL
Compound 4: the middle estimate sits 1.4-fold (0.15 log units) below what was measured, and the stated range covers the measured number.
By their numbers in this assay, from the lowest: compound 3; then compounds 4, 2 and 1 (each within the scatter of the next, the first and the last beyond it).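

Turning over this one ring carbon gives a 2.2-fold higher number from compound 3 to compound 4 (0.34 log units; beyond the scatter) and so shows that configuration alone shifts the number at a second stereocentre, not only at the one seen earlier: the fact that compounds 3 and 4 differ only in the configuration as drawn. With both stereocentres changed, the outcome is a 1.4-fold lower number from compound 2 to compound 4 (0.16 log units; within the scatter) and the two changes together leave no difference beyond the scatter: the fact that compounds 2 and 4 differ only in the configuration as drawn. The compounds shown leave open whether the same sensitivity to configuration holds in the acetylated series of compound 1. They also leave open how an amine or a carboxylic acid at this ring carbon would shift the number.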